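Swapping Methoxy for Hydroxymethyl on the Aromatic Ring

The compounds below may be only part of what the source reports. "The series", "measured", "known", "first", "only" and "open" are said of these compounds alone.

Of the compounds shown here, two have so far been tested in an assay on HEK293 cells for inhibition of N-acylethanolamine-hydrolyzing acid amidase (Rattus norvegicus), read by LC-MS, with a stated time of 30 min; on this read-out lower numbers stand for stronger inhibition and higher numbers for weaker inhibition. Compound 1 `CSc1cccc(CCCCCC(=O)N2CCOC2=O)c1` carries a methylsulfanyl group on its aromatic ring, and in this assay compound 1 gives 12800 nM. Compound 2 `COc1cccc(CCCCCC(=O)N2CCOC2=O)c1` carries a methoxy group at that same carbon, and in this assay compound 2 gives 16300 nM. Compound 2 stands at the top of the two numbers shown, but the step of a 1.3-fold higher number from compound 1 to compound 2 (0.10 log units; within the scatter) lies within the scatter, so the two compounds cannot be told apart on these data.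

Compound 3 `O=C(CCCCCc1cccc(CO)c1)N1CCOC1=O` has not yet been measured. It differs from compound 2 by hydroxymethyl in place of methoxy on an aromatic carbon. Among the measured compounds shown here, only one measured step touches this aromatic carbon, and that step, a 1.3-fold higher number from compound 1 to compound 2 (0.10 log units; within the scatter), was within the scatter. Nothing measured shows what a hydroxymethyl group does at this place, so no step beyond the scatter is expected in this assay. The estimate for compound 3 is 18000 nM, with a range from 7000 nM to 45000 nM, which means an expected step of a 1.1-fold higher number from compound 2 to compound 3 (0.04 log units; within the scatter).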

Compound 3, half-maximal inhibitory concentration: > 20000 nM
Compound 3: no number, only a limit (the forecaster's own chance of this, stated with the estimate: 10%); middle value at least 1.1-fold (0.04 log units) away from the limit.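

Compound 3 gives only a limit, not a number, in this assay: the limit of > 20000 nM in this assay, at which 1 of the 3 values shown sits.

The limit still fixes a direction at this aromatic carbon: the swap from methoxy gives an at least 1.2-fold higher number from compound 2 to compound 3 (0.08 log units; that floor lies within the scatter), and the swap from methylsulfanyl gives an at least 1.5-fold higher number from compound 1 to compound 3 (0.19 log units; that floor lies within the scatter), yet both floors lie within the scatter, so compound 3 cannot yet be told apart from either neighbour. What is new is the kind of change tested: methoxy and hydroxymethyl hold the same atoms joined differently, hydroxymethyl brings a hydrogen-bond donor that methoxy lacks, and this change gave no stronger inhibition, a question that the earlier pair could not address.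

As far as these compounds go, the true number for compound 3 remains open, and with it whether the swap has a real effect on inhibition or only a small one, and the data cannot say what role, if any, the hydrogen-bond donor plays. Also open, from the compounds shown here alone, is whether a different group on this aromatic carbon, such as an amine or a carboxylic acid, would bring the number down.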